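A few compounds are considered here, and "the series" means these few. Any claim that something is new, unique, unknown or untested is made for them only; others in the source may bear on it.

Compound 1 `CC1=CC[C@H](C(C)C)c2cc(C)c(OC(=O)c3ccc(C)cc3)cc21` gives 100% in a functional assay on K562 cells (Homo sapiens) for antiproliferative activity, read by sulforhodamine B assay, with a stated time of 48 h, tested at 50 uM (a higher number here means more inhibition at the concentration tested (going by the name of the read-out), a lower number less inhibition), and stands highest of the two compounds measured there. Compound 2 `Cc1cc2c(C(C)C)ccc(C)c2cc1OC(=O)c1ccc(C(F)(F)F)cc1`, built on a different core, gives 45.1% in this assay, a much lower number. Compound 3 `CC1=CC[C@H](C(C)C)c2cc(C)c(OC(=O)c3ccc(Cl)cc3)cc21` has not yet been tested; it differs from compound 1 by chloro in place of methyl on an aromatic carbon. For the measured compounds named here, no step between two measured compounds shows how such a change behaves here, so the expectation for compound 3 rests on the number of compound 1 alone. The step of a number 15 percentage points lower from compound 1 to compound 3 (beyond the scatter) is expected to be modest, downward or none beyond the scatter. Compound 3 is estimated at 85%, within 55% to 100%.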

Compound 3, a percentage reported as inhibition, at one concentration (the size of the read-out at that concentration, not a potency): 58.9%
The estimate for compound 3 lay 26.1 percentage points above the measured number; the range from low to high includes it.
By their numbers in this assay, from the lowest: compound 2; then compound 3; then compound 1.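

In this assay, the aromatic carbon para to a large group proves sensitive: with chloro in place of methyl, the read-out falls, a number 41.1 percentage points lower from compound 1 to compound 3 (beyond the scatter), on an otherwise unchanged core. The change from 4-methylphenyl to 4-chlorophenyl adds no ring, hydrogen-bond donor, hydrogen-bond acceptor or net charge, yet the step is large. No measurement at hand accounts for this step.

As far as these compounds go, whether a methoxy group, an amine or a carboxylic acid at this position would also lower the number remains open. With only chloro read here, it is also unknown whether the loss is particular to chloro or follows other replacements of methyl.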